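This account rests on a few compounds, and the source may have more. Where it says the series, first, only, none or still open, it means among the compounds named here.

Compound 2, `CCCCCc1ccc(NC(=O)N[C@@H](C)c2ccccc2)cc1`, is measured in an ADME assay on the whole organism with Oryza sativa as the target, tested at 0.1 uM (on this read-out higher numbers stand for a weaker effect at the one concentration tested and lower numbers for a stronger effect), and gives 98%. Two related compounds have been measured alongside it. Compound 1, `CCCCCc1ccc(NC(=O)N[C@H](C)c2ccccc2)cc1`, gives 100% in this assay, and compound 3, `C[C@H](NC(=O)Nc1cccc(F)c1)c1ccccc1`, gives 97%. On these three numbers compound 2 sits in the middle, and all three lie within the scatter of one another, so none of them can be set apart from the others.

Within the data shown here, only one step between measured compounds is available: a number 2 percentage points lower from compound 1 to compound 2 (within the scatter). This rests on (the fact that compounds 1 and 2 differ only in the configuration as drawn), so a swap of configuration alone leaves the read-out unchanged within the scatter.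

The next compound, compound 4, `C[C@H](NC(=O)Nc1ccc(F)cc1)c1ccccc1`, differs from compound 2 by fluoro in place of pentyl on an aromatic carbon. Among the measured compounds shown here, no measured step describes a change of this kind; the one step known concerns configuration, not the exchange of a group, and compound 3, which carries a fluoro, shows a number within the scatter of compound 2 without any step to compound 2 being defined. With all three measured numbers within the scatter of one another, the expectation is a number 1 percentage points lower from compound 2 to compound 4 (within the scatter), no change beyond the scatter. Compound 4 is therefore estimated at 97%, within a range of 85% to 100%.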

Compound 4, a percentage reported as activity, at one concentration (the size of the read-out at that concentration, not a potency): 96%
Estimate against measurement, compound 4: 1 percentage points above, within the range that was stated.
By their numbers in this assay, from the lowest: compounds 4, 3, 2 and 1 (each within the scatter of the next).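

In this assay, putting a fluoro in place of pentyl on an aromatic carbon, para to a large group, gives a number 2 percentage points lower from compound 2 to compound 4 (within the scatter). Among these compounds, until now the only readable step was a swap of configuration, so this is the first sign that exchanging the group itself at this place can also leave the read-out inside the scatter, even though the substituent goes from 5 heavy atoms, all carbon, to 1 heavy atom, a fluorine. Nothing available explains why these two groups cannot be told apart on this read-out.

From the compounds shown here alone, whether any group at this place can move the number beyond the scatter remains open, since only pentyl and fluoro have been compared here, and an amine, a carboxylic acid or a longer chain might behave differently. With a single tested concentration, the result also cannot show whether compound 2 and compound 4 would still match at other concentrations.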